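The compounds below may be only part of what the source reports. "The series", "measured", "known", "first", "only" and "open" are said of these compounds alone.

Compound 1 `CN1CCN(c2nc(NCC(=O)NCc3ccccc3)c3ccccc3n2)CC1` was tested in an ADME assay on HEK-293T cells (Homo sapiens) for cytotoxicity, read by CCK-8 assay, with a stated time of 48 h; a lower number here means that less compound is tolerated, a higher number that more compound is tolerated. In this assay compound 1 gives > 100000 nM, which is a limit of the assay rather than a number. Compound 2 `O=C(CSc1nc(N2CCCC2)nc2ccccc12)NCc1ccc2ccccc2c1` was tested in the same way. In this assay compound 2 gives > 100000 nM, again a limit and not a measured number. Among the compounds with values here, both measured compounds therefore sit at the limit of > 100000 nM in this assay, at which 2 of the 2 values shown sit, so no step between measured compounds is available to guide expectations. Compound 3 `O=C(CNc1nc(N2CCc3ccccc3C2)nc2ccccc12)NCc1ccccc1` has not yet been measured. It differs from compound 1 in one place: 1,2,3,4-tetrahydroisoquinolin-2-yl in place of 4-methylpiperazin-1-yl on an aromatic carbon Without a measured step of this kind, no change in this assay beyond the usual scatter is expected, though a reading that falls below the limit cannot be ruled out. For compound 3 in this assay the expected value is 100000 nM, within a range from 30000 nM to 300000 nM. The step of a number no higher from compound 1 to compound 3 (the limit leaves the size open) is thus expected to stay within the scatter.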

Compound 3, half-maximal cytotoxic concentration: 29400 nM
Estimate against measurement, compound 3: 3.4-fold (0.53 log units) above; the measured number lies below the stated range.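

Putting 1,2,3,4-tetrahydroisoquinolin-2-yl in place of 4-methylpiperazin-1-yl on this aromatic carbon gives an at least 3.4-fold lower number from compound 1 to compound 3 (0.53 log units; beyond the scatter) in this assay. This is the first change shown that brings a reading off the limit, so the group on the aromatic carbon between two ring nitrogen atoms does bear on how much compound the cells tolerate. The full size of the step stays open, because compound 1 has only a limit and not a number: the limit of > 100000 nM in this assay, at which 2 of the 3 values shown sit.

The compounds shown cannot tell whether the added aromatic ring of carbon only or the loss of the second ring nitrogen goes with the step. A piperidin-1-yl group, which has neither that aromatic ring nor a second ring nitrogen, would help separate the two at this position.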